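Notes on a phenyl to methyl step

This account rests on a few compounds, and the source may have more. Where it says the series, first, only, none or still open, it means among the compounds named here.

In a functional assay on KG-1 cells (Homo sapiens) for cytotoxicity, read by luminescence and CellTiter-Glo, with a stated time of 3 days (on this read-out lower numbers stand for stronger inhibition and higher numbers for weaker inhibition), compound 1 (`N#Cc1ccc(NC(=O)c2cc(-c3ccccc3)ccc2O)cc1`) gives 1300 nM while compound 2 (`O=C(Nc1ccc(C(F)(F)F)cc1)c1cc(Br)c(F)cc1O`) gives 820 nM and these two values lie within the scatter of each other. Among the compounds with values here, compound 1 therefore stands level with the only other measured compound, and the numbers show no order between them.

Compound 3 (`Cc1ccc(O)c(C(=O)Nc2ccc(C#N)cc2)c1`) has not yet been measured. It differs from compound 1 in one place (methyl in place of phenyl on an aromatic carbon) with methyl in place of phenyl on an aromatic carbon, para to a hydroxy group. Within the data shown here, no measured pair shows this change, so the size of the step cannot be read from the data and the expectation remains a judgement. A moderate step towards a higher number, meaning weaker inhibition, is expected. Compound 2 carries no phenyl and still gives 820 nM so a complete loss of activity is not expected. The expected size of the step is a 2.3-fold higher number from compound 1 to compound 3 (0.36 log units; beyond the scatter) with wide uncertainty. For compound 3 the estimated value is 3000 nM with an expected range from 1000 nM to 10000 nM as the likely span of measurements.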

Compound 3, half-maximal inhibitory concentration: 3370 nM
Compound 3: middle estimate off by 1.1-fold (0.05 log units), on the low side; low and high end bracket the measured number.
By their numbers in this assay, from the lowest: compounds 2 and 1 (each within the scatter of the next); then compound 3.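

In this assay, within the data shown here, methyl in place of phenyl on this aromatic carbon, para to a hydroxy group, gives a 2.6-fold higher number from compound 1 to compound 3 (0.41 log units; beyond the scatter), the first step to lie beyond the scatter. The group on this carbon therefore moves the number, with phenyl on the lower side, but the step is modest and a six-membered aromatic ring here is not needed for compound 3 to give a measurable 3370 nM. Nothing at hand accounts for the size of this step.

Open, going by these compounds, is how the number would run with an ethyl, a cyclohexyl or a pyridyl group on this carbon, which would show whether it follows the aromatic ring itself or simply the size of the group. Among these compounds, compound 2 differs from compound 1 and compound 3 in more than one place, so it gives no step at this position, and this single pair cannot show whether the change would have the same size on another core.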